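Sulfonamide series: chain homologation and acid dissociation

The source may hold more compounds than are shown below. What is called first, only, known or untested is meant among the compounds shown, and "the series" means these compounds.

Measured so far:
compound 1, `NS(=O)(=O)c1ccc(SCCO)c(F)c1`: 9.76
compound 2, `NS(=O)(=O)c1ccc(SCCCO)c(F)c1`: 9.64
compound 3, `NS(=O)(=O)c1ccc(SCCCO)s1`: 9.32

In a physicochemical assay for acid dissociation, compound 1 gives 9.76 and compound 2 gives 9.64. The two differ by hydroxymethyl in place of hydroxy on a saturated chain carbon, two bonds along the chain from a sulfur, and the step is a number 0.12 log units lower from compound 1 to compound 2 (within the scatter). Compound 3 gives 9.32 in this assay, the lowest of the three numbers; the difference between its core and the core of compound 1 is not broken down here. Compound 4, `NS(=O)(=O)c1ccc(SCCCCO)s1`, is not yet measured. It differs from compound 3 by hydroxymethyl in place of hydroxy on a saturated chain carbon, three bonds along the chain from a sulfur. This is the same kind of change as that from compound 1 to compound 2, but the place differs: two bonds along the chain from a sulfur there, three bonds along the chain from a sulfur here. Because the step of a number 0.12 log units lower from compound 1 to compound 2 (within the scatter) stayed within the scatter, a step of similar size is expected, a number 0.07 log units lower from compound 3 to compound 4 (within the scatter). Compound 4 is estimated at 9.25, within 8.95 to 9.55.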

Compound 4, acid dissociation constant: 9.5
For compound 4 the middle estimate is 0.25 log units below the measured one; measured number inside the range.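

In this assay the change from hydroxy to hydroxymethyl gives a number 0.12 log units lower from compound 1 to compound 2 (within the scatter) on one core and a number 0.18 log units higher from compound 3 to compound 4 (within the scatter) on the other, so in both series pairs the step stays within the scatter. That is a single pair per core, with the change at a different place on the chain in each, and it does not show that a step of fixed size or direction carries from one core to another. Nothing shown speaks to what sets the size of either step.

The compounds shown leave open how a chain longer than 4-hydroxybutyl would read on either core. They also leave open whether an amine or a carboxylic acid in place of hydroxy would stay within the scatter.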